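This account rests on a few compounds, and the source may have more. Where it says the series, first, only, none or still open, it means among the compounds named here.

Compound 1 `FC(F)(F)c1cccc(NC(=S)Nc2ccc(Cl)cc2)c1`: 11000 nM
Compound 2 `COc1cccc(NC(=S)Nc2cccc(C(F)(F)F)c2)c1`: 20000 nM
Compound 3 `FC(F)(F)c1cccc(NC(=S)Nc2cccc(Br)c2)c1`: 14000 nM

In an ADME assay on Vero 76 cells (Chlorocebus sabaeus) for cytotoxicity, read by crystal violet staining, with a stated time of 96 h (on this read-out lower numbers stand for higher toxicity in this test and higher numbers for lower toxicity in this test), compound 3 gives 14000 nM, which places it within the scatter of both other measured compounds. The two steps that reach it show this: a 1.3-fold higher number from compound 1 to compound 3 (0.10 log units; within the scatter) and a 1.4-fold lower number from compound 2 to compound 3 (0.15 log units; within the scatter).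

The next compound to be tested is compound 4 `FC(F)(F)c1cccc(NC(=S)Nc2ccccc2Br)c1`, which has 2-bromophenyl in place of 3-bromophenyl on an amide-type nitrogen. The two compounds have the same atoms, joined differently.

Among the measured compounds shown here, no measured compound carries 2-bromophenyl, so the evidence for this change is indirect. The closest comparison is the exchange on the same kind of nitrogen, 3-bromophenyl in place of 4-chlorophenyl, seen in a 1.3-fold higher number from compound 1 to compound 3 (0.10 log units; within the scatter). The exchange of bromo in place of methoxy on an aromatic carbon, seen in a 1.4-fold lower number from compound 2 to compound 3 (0.15 log units; within the scatter), is also small. Neither step gives a reason to expect a direction, so no change beyond the scatter is expected in this assay.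

The expected step is a 1.1-fold higher number from compound 3 to compound 4 (0.03 log units; within the scatter). For compound 4 the estimated value is 15000 nM, with an expected range from 8000 nM to 30000 nM.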

Compound 4, half-maximal cytotoxic concentration: 50000 nM
Compound 4: middle estimate off by 3.3-fold (0.52 log units), on the low side, outside the stated range (above it).
By their numbers in this assay, from the lowest: compounds 1, 3 and 2 (each within the scatter of the next); then compound 4.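

In this assay, among the compounds shown here, exchanging 3-bromophenyl for 2-bromophenyl on the amide-type nitrogen, with the same atoms joined differently, gives a 3.6-fold higher number from compound 3 to compound 4 (0.55 log units; beyond the scatter), so where the bromine sits on this ring changes the number beyond the scatter, which none of the earlier steps had done. The exchange of 4-chlorophenyl for 2-bromophenyl on the same nitrogen points the same way, with a 4.5-fold higher number from compound 1 to compound 4 (0.66 log units; beyond the scatter), and on this read-out both steps mean lower toxicity in this test. Nothing measured here accounts for the shift, so the result stands as an observation without a known cause.

The compounds shown leave open whether the higher number belongs to bromine alone or would also appear with other groups in the same ring position, such as 2-chlorophenyl, 2-methoxyphenyl or a 2-aminophenyl ring. They also leave open whether 4-bromophenyl would sit with compound 3 or with compound 4, and whether the step would persist if the thiocarbonyl carbon became a carbonyl.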